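Amide side-chain acids in the pyrrole series

The source may hold more compounds than are shown below. What is called first, only, known or untested is meant among the compounds shown, and "the series" means these compounds.

Measured so far:
- compound 1 `CCn1c(C(=O)NCCC(=O)OC)ccc1C(CC)(CC)c1ccc(OCS(=O)(=O)c2ccccc2)c(C)c1`, > 50000 nM in a functional assay on BXPC-3 cells (Homo sapiens) for antiproliferative activity, read by MTT assay, with a stated time of 24 h; a lower number here means a stronger inhibitor, a higher number a weaker inhibitor — a limit
- compound 2 `CCn1c(C(=O)NCCNC(=O)OC(C)(C)C)ccc1C(CC)(CC)c1ccc(OCS(=O)(=O)c2ccccc2)c(C)c1`, > 50000 nM — a limit
- compound 3 `CCn1c(C(=O)N[C@H](C)C(=O)O)ccc1C(CC)(CC)c1ccc(OCS(=O)(=O)c2ccccc2)c(C)c1`, 20100 nM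

Compound 2 stands only at a limit in this assay, as the line the limit of > 50000 nM in this assay, at which 2 of the 3 values shown sit, records for two of the three values. Compound 4 `CCn1c(C(=O)NCCC(=O)O)ccc1C(CC)(CC)c1ccc(OCS(=O)(=O)c2ccccc2)c(C)c1` carries the change (carboxy in place of (tert-butoxycarbonyl)amino on a saturated chain carbon, two bonds along the chain from an amide-type nitrogen). The step that bears on it is an at least 2.4-fold lower number from compound 2 to compound 3 (0.39 log units; beyond the scatter), where a free carboxy group replaced the protected amine; an at least 2.4-fold lower number from compound 1 to compound 3 (0.39 log units; beyond the scatter) points the same way from the ester. A step of similar size is expected here, so compound 4 is estimated at an at least 2.0-fold lower number from compound 2 to compound 4 (0.30 log units; that floor lies within the scatter). The expected value for compound 4 is 25000 nM, between 10000 nM and 60000 nM.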

Compound 4, half-maximal inhibitory concentration: > 50000 nM
Compound 4 was reported as a limit; the forecaster's own chance of this, stated with the estimate: 35%; middle value at least 2.0-fold (0.30 log units) away from the limit.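

In this assay compound 4 gives > 50000 nM which is a limit, so a free carboxy group on the chain does not by itself give a readable value: the limit of > 50000 nM in this assay, at which 3 of the 4 values shown sit. With 2-carboxyethyl in place of 1-carboxyethyl on the amide-type nitrogen, the series shows an at least 2.4-fold higher number from compound 3 to compound 4 (0.39 log units; beyond the scatter) so the placement of the carboxy group on the chain matters, not just its presence. The steps from compound 1 and compound 2 to compound 4 cannot be read, as both ends are limits.

Still open, as far as these compounds go, is whether the methyl branch or the chain length separates these two acids. A carboxymethyl chain, a 3-carboxypropyl chain or a 2-aminoethyl chain on the same nitrogen would test this.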